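Ester-capped piperidine replaces piperazine on the spiro-lactam amide

The compounds below may be only part of what the source reports. "The series", "measured", "known", "first", "only" and "open" are said of these compounds alone.

This account follows a single change made to compound 1 `CC(C)(C)c1ccc(C(=O)N2CCC3(CC2)C(=O)N(CC(=O)N2CCNCC2)CN3c2ccccc2)cc1`. In an assay on HEK293 cells for displacement of a labelled ligand from NPC1-like intracellular cholesterol transporter 1 (Homo sapiens) (a higher number here means a weaker inhibitor, a lower number a stronger inhibitor), compound 1 gives 22000 nM, the highest of the two numbers recorded, and a weaker inhibitor than compound 2 `CC(C)(C)OC(=O)N1CCN(C(=O)CN2CN(c3ccccc3)C3(CCN(C(=O)c4ccc(C5CCCCC5)cc4)CC3)C2=O)CC1`, which in this assay gives 3500 nM. Compound 2 differs from compound 1 in more than one place, so the two values are only compared, not decomposed.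

The new compound 3 `CCOC(=O)C1CCCN(C(=O)CN2CN(c3ccccc3)C3(CCN(C(=O)c4ccc(C(C)(C)C)cc4)CC3)C2=O)C1` is drawn from compound 1 by one substitution: 3-(ethoxycarbonyl)piperidin-1-yl in place of piperazin-1-yl on a carbonyl carbon. The piperazin-1-yl that leaves carries the only hydrogen-bond donor of that fragment; the 3-(ethoxycarbonyl)piperidin-1-yl that enters carries none and adds a second acceptor.

Because compound 2 gives 3500 nM with its piperazine nitrogen carrying a carbamate, a lower number is expected for compound 3, as the step of a 2.8-fold lower number from compound 1 to compound 3 (0.44 log units; beyond the scatter), a modest step beyond the scatter. Compound 3 is therefore estimated at 8000 nM, with a range from 2500 nM to 25000 nM.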

Compound 3, half-maximal inhibitory concentration: 8200 nM
Beside the measured number, compound 3's estimate is 1.0-fold (0.01 log units) below it; the range from low to high includes it.
By their numbers in this assay, from the lowest: compound 2; then compound 3; then compound 1.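

In this assay, among the compounds shown here, placing 3-(ethoxycarbonyl)piperidin-1-yl in place of piperazin-1-yl on this carbonyl carbon gives a 2.7-fold lower number from compound 1 to compound 3 (0.43 log units; beyond the scatter) and is the first step here that can be read at a single position. It shows that the group on this carbonyl carbon need not carry a hydrogen-bond donor for the number to fall, since the entering group has none. The change swaps the ring, removes the donor and adds the ester together, and no measurement shown here separates these parts or accounts for the step.

A plain piperidin-1-yl, or a carboxylic acid in place of the ethyl ester, would show whether the ester contributes to the step or the ring change alone carries it. Going by these compounds, it also remains open whether the same exchange moves the number similarly when cyclohexyl replaces tert-butyl on the benzoyl group.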